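The source may report more compounds than this note shows. Statements on the series, on what has been measured and on what is new or still open speak of the compounds shown alone.

Compound 1 `COc1ccc(/C=C/C(=O)/C=C/c2nc3cc(C)ccc3n2C)cc1O`: 4800 nM
Compound 2 `COc1ccc(/C=C/C(=O)/C=C/c2nc3cc(Cl)ccc3n2C)cc1O`: 4800 nM

In a functional assay on SH-SY5Y cells (Homo sapiens) for cytotoxicity, read by MTT assay, with a stated time of 48 h (a lower number here means a stronger inhibitor, a higher number a weaker inhibitor), compound 1 stands level with compound 2 at 4800 nM. Compound 3 `COc1ccc(/C=C/C(=O)/C=C/c2nc3cc(O)ccc3n2C)cc1O` is the next member of the series, with hydroxy in place of chloro on an aromatic carbon. Within the data shown here, only one measured step bears on this change, no change at the digits printed from compound 1 to compound 2 (within the scatter), with chloro in place of methyl, and it lies within the scatter. Among the measured compounds shown here, no measured step involves hydroxy, so the range is kept wide, and no step beyond the scatter is expected. Compound 3 is estimated at 5000 nM, with an expected range of 2000 nM to 12000 nM. The expected step is a 1.0-fold higher number from compound 2 to compound 3 (0.02 log units; within the scatter).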

Compound 3, half-maximal inhibitory concentration: 4600 nM
Estimate against measurement, compound 3: 1.1-fold (0.04 log units) above; the measured number falls inside the stated range.
By their numbers in this assay, from the lowest: compounds 3, 1 and 2 (each within the scatter of the next).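

In this assay, hydroxy on this aromatic carbon brings a hydrogen-bond donor and acceptor, and the comparison with chloro gives a 1.0-fold lower number from compound 2 to compound 3 (0.02 log units; within the scatter) while the comparison with methyl gives a 1.0-fold lower number from compound 1 to compound 3 (0.02 log units; within the scatter). Methyl, chloro and hydroxy thus all lie within the scatter of one another at this place, now including a group with a hydrogen-bond donor. No supporting measurement bears on the reason for this result.

Open, from the compounds shown here alone, is whether an amine, a carboxylic acid or a longer alkoxy chain here would stay level. These compounds also cannot show whether this level holds in any other read-out.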